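Furan to pyridine swap on two aminopyrimidine cores

A few compounds are considered here, and "the series" means these few. Any claim that something is new, unique, unknown or untested is made for them only; others in the source may bear on it.

Measured so far:
- compound 1, `c1ccc(-c2ccnc(Nc3ccc(-n4ccnc4)cc3)n2)nc1`: 1400 nM
- compound 2, `c1coc(-c2ccnc(Nc3ccc(-n4ccnc4)cc3)n2)c1`: 2200 nM
- compound 3, `COc1cccc(Nc2nccc(-c3ccco3)n2)c1`: 400 nM

In a functional assay for inhibition, with Homo sapiens as the target (on this read-out higher numbers stand for weaker inhibition and lower numbers for stronger inhibition), compound 3 gives the lowest number of the three. Compound 2 carries a furan-2-yl, compound 1 a pyridin-2-yl; the difference is pyridin-2-yl in place of furan-2-yl on an aromatic carbon, and the step is a 1.6-fold lower number from compound 2 to compound 1 (0.20 log units; within the scatter). Compound 3 and compound 2 are built on different cores; the difference between the two cores is not broken down here.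

Compound 4, `COc1cccc(Nc2nccc(-c3ccccn3)n2)c1`, has not been measured. It differs from compound 3 by pyridin-2-yl in place of furan-2-yl on an aromatic carbon. This is the same kind of change as that from compound 2 to compound 1, not the same: in compound 3 the aromatic carbon is meta to a group of 9 heavy atoms, whereas in compound 2 it is meta to a large group.

For compound 4 the step of a 1.4-fold lower number from compound 3 to compound 4 (0.15 log units; within the scatter) is expected, of a size beside the earlier one, because the only precedent is a 1.6-fold lower number from compound 2 to compound 1 (0.20 log units; within the scatter), which lies within the scatter; nothing shown suggests a larger shift on the core of compound 3. Compound 4 is therefore estimated at 280 nM in this assay, with a range from 120 nM to 650 nM. The pattern rests on a single pair, compound 2 and compound 1, and no listed compound tests it on another core.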

Compound 4, half-maximal inhibitory concentration: 200 nM
Beside the measured number, compound 4's estimate is 1.4-fold (0.15 log units) above it; the measured number falls inside the stated range.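

In this assay, pyridin-2-yl in place of furan-2-yl on an aromatic carbon gives a 2.0-fold lower number from compound 3 to compound 4 (0.30 log units; within the scatter), so on the core of compound 3 the change cannot be told from the usual spread of repeated measurements. Set against the earlier pair, the two steps cannot be told apart either, and the change reads alike on both cores: the same change on two cores in this assay, a 1.6-fold lower number (0.20 log units; within the scatter) from compound 2 to compound 1 and a 2.0-fold lower number (0.30 log units; within the scatter) from compound 3 to compound 4, 1.3-fold (0.10 log units) apart, within the scatter of two such steps

This shows that, on these two cores, the swap carries over without a step that stands clear of the scatter, but it does not show that pyridin-2-yl is better than furan-2-yl on either core, and two pairs give no basis for predicting the step on a third core.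

The compounds shown leave open whether the small step holds for other groups on the same aromatic carbon, such as a phenyl ring, an amine or a carboxylic acid, where a step beyond the scatter might or might not appear. They also leave open how the swap behaves on a core carrying something else in place of the aryl amino part, for example a longer chain or an amide.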